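Quinolin-6-yl for Pyridin-3-yl, Tried on Two Cores

The source may hold more compounds than are shown below. What is called first, only, known or untested is meant among the compounds shown, and "the series" means these compounds.

The measured compounds and their numbers:
compound 1, `O=C(O[C@H]1C[C@H](n2cc(F)c(=O)[nH]c2=O)O[C@@H]1COP(=O)(O)Oc1cccnc1)c1ccccc1`, gives 15600 nM in a functional assay on MRC5 cells (Homo sapiens) for cytotoxicity, read by MTT assay, with a stated time of 48 h; a lower number here means a stronger inhibitor, a higher number a weaker inhibitor;
compound 2, `O=C(O[C@H]1C[C@H](n2cc(F)c(=O)[nH]c2=O)O[C@@H]1COP(=O)(O)Oc1ccc2ncccc2c1)c1ccccc1`, gives 1300 nM;
compound 3, `O=c1[nH]c(=O)n([C@H]2C[C@H](O)[C@@H](COP(=O)(O)Oc3cccnc3)O2)cc1F`, gives 8500 nM.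

Compound 1 and compound 2 differ in one place, (quinolin-6-yl in place of pyridin-3-yl on an oxygen), and that change gave a 12-fold lower number from compound 1 to compound 2 (1.08 log units; beyond the scatter). Compound 3 shares most of its structure with compound 1 but differs at one point, (hydrogen in place of benzoyl on an oxygen on a saturated carbon), and that difference gave a 1.8-fold lower number from compound 1 to compound 3 (0.26 log units; within the scatter). Compound 3 thus stands close to compound 1 in this assay, and the two are far from compound 2, which gives the lowest number of the three.

Compound 4, `O=c1[nH]c(=O)n([C@H]2C[C@H](O)[C@@H](COP(=O)(O)Oc3ccc4ncccc4c3)O2)cc1F`, has not yet been measured in this assay. It differs from compound 3 in one place, (quinolin-6-yl in place of pyridin-3-yl on an oxygen). This is the same change that separates compound 1 from compound 2, made at the same place, on an oxygen whose other neighbours are phosphorus. Among the compounds shown this change occurs twice in all, once measured and once not.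

For the measured compounds named here, on that basis the step from compound 3 to compound 4 is expected to be a 9.4-fold lower number from compound 3 to compound 4 (0.98 log units; beyond the scatter), somewhat smaller than the measured one, because a 12-fold lower number from compound 1 to compound 2 (1.08 log units; beyond the scatter) is the only prior example of the change and compound 3 carries a hydroxy group where compound 1 carries benzoyloxy. Compound 4 is therefore estimated at 900 nM, with an expected range from 300 nM to 3000 nM.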

Compound 4, half-maximal inhibitory concentration: 1300 nM
For compound 4 the middle estimate is 1.4-fold (0.16 log units) below the measured one, and the stated range covers the measured number.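

In this assay, for the compounds shown here, quinolin-6-yl in place of pyridin-3-yl gave a 6.5-fold lower number from compound 3 to compound 4 (0.82 log units; beyond the scatter), so the change carried over to the core with the free hydroxy group at a size that matches the earlier step: the same change on two cores in this assay, a 12-fold lower number (1.08 log units; beyond the scatter) from compound 1 to compound 2 and a 6.5-fold lower number (0.82 log units; beyond the scatter) from compound 3 to compound 4, 1.8-fold (0.26 log units) apart, within the scatter of two such steps Hydrogen in place of benzoyl was also consistent, giving no change at the digits printed from compound 2 to compound 4 (within the scatter), which agrees with the step seen among the pyridin-3-yl compounds: the same change on two cores in this assay, a 1.8-fold lower number (0.26 log units; within the scatter) from compound 1 to compound 3 and no change at the digits printed (within the scatter) from compound 2 to compound 4, 1.8-fold (0.26 log units) apart, within the scatter of two such steps Within these four compounds, each change therefore gave a similar result whichever group stood at the other place, but this rests on only two pairs per change in a single assay, and it neither shows that the same would hold on any other core nor explains why the quinolin-6-yl compounds give the lower numbers.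

The compounds shown leave open how a plain phenyl group or a naphthalen-2-yl group would compare with quinolin-6-yl on the oxygen whose other neighbours are phosphorus. They also leave open whether an acetyl group or a longer acyl chain in place of benzoyl on the oxygen on a saturated carbon would likewise leave the number within the scatter.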